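This account rests on a few compounds, and the source may have more. Where it says the series, first, only, none or still open, it means among the compounds named here.

Measured so far in an ADME assay on HepG2 cells (Homo sapiens) for cytotoxicity, in the presence of a further agent that is not named here; on this read-out higher numbers stand for weaker inhibition and lower numbers for stronger inhibition:

Compound 1 `Cn1c(Cc2ccccc2C(F)(F)F)nc(C(=O)NCc2cccnc2)c(O)c1=O`: the value > 100000 nM is a limit of the assay, not a number.
Compound 2 `CN(Cc1ccccc1)C(=O)c1nc(Cc2ccccc2C(F)(F)F)n(C)c(=O)c1O`: the value > 100000 nM is likewise a limit.
Compound 3 `CC(c1ccccc1C(F)(F)F)c1nc(C(=O)NCc2ccccc2)c(O)c(=O)n1C`: the value > 100000 nM is likewise a limit.

Compound 1 therefore stands at the limit of this assay, and so do the two other compounds (the limit of > 100000 nM in this assay, at which 3 of the 3 values shown sit). Going by the values given here, the only single-site step among the measured compounds, a step that the two limits leave unreadable from compound 1 to compound 2, cannot be read in size or direction, since both ends are limits.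

Compound 4 `Cn1c(Cc2ccccc2C(F)(F)F)nc(C(=O)NCc2ccccc2)c(O)c1=O`, not yet measured, differs from compound 1 as follows: phenyl in place of pyridin-3-yl on a saturated chain carbon bound to an amide-type nitrogen. Among the compounds with values here, no measured step bears on this change in a readable way; the one step available, a step that the two limits leave unreadable from compound 1 to compound 2, is unreadable, and the step from compound 2 to compound 3 or from compound 1 to compound 3 is not a single-site change. Nothing in the series gives a reason to expect a readable difference for compound 4 from compound 1 in this assay.

Compound 4 is therefore expected to sit at the limit again, estimated at 100000 nM, range 50000 nM to 300000 nM. The expected step of a number no higher from compound 1 to compound 4 (the limit leaves the size open) is nominal only, and most likely the assay will again report a limit rather than a number.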

Compound 4, half-maximal inhibitory concentration: > 100000 nM
Compound 4: only a limit was reported (the forecaster's own chance of this, stated with the estimate: 85%); the middle value sits exactly at the limit.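

In this assay compound 4 gives > 100000 nM, a limit and not a number, so no new step from compound 1, compound 2 or compound 3 to compound 4 can be read: the limit of > 100000 nM in this assay, at which 4 of the 4 values shown sit.

Whether any of these changes shifts the values in this assay at all, and by how much, stays open with the compounds shown.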